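The source may report more compounds than this note shows. Statements on the series, on what has been measured and on what is new or still open speak of the compounds shown alone.

Compound 1 `COc1cc2c(/C=C3/C(=O)Nc4ccc(Cl)cc43)c(Cl)n(Cc3cc(OC)c(OC)c(OC)c3)c2cc1C` and compound 2 `COc1ccc2c(c1)/C(=C\c1c(Cl)n(Cc3cc(OC)c(OC)c(OC)c3)c3cc(C)c(OC)cc13)C(=O)N2` share one core and differ in a single spot: methoxy in place of chloro on an aromatic carbon In a functional assay on cells (Cancer cell lines, Homo sapiens) for cytotoxicity, with a stated time of 48 h (a lower number here means a stronger inhibitor of growth, a higher number a weaker inhibitor of growth), compound 1 gives 2090 nM and compound 2 gives 10200 nM, so that change made a 4.9-fold higher number from compound 1 to compound 2 (0.69 log units; beyond the scatter). Compound 3 `COc1c(/C=C2/C(=O)Nc3ccc(Cl)cc32)c2ccccc2n1-c1ccccc1` is built on a different core; how that core differs from the core of compound 1 is not broken down here. In this assay compound 3 gives 4270 nM. Compound 4 `COc1ccc2c(c1)/C(=C\c1c(OC)n(-c3ccccc3)c3ccccc13)C(=O)N2` is not yet measured and stands to compound 3 as compound 2 stands to compound 1: methoxy in place of chloro on an aromatic carbon The place is described in identical words for both pairs, so it is the same change. The expected step is a 3.5-fold higher number from compound 3 to compound 4 (0.55 log units; beyond the scatter), because the same change in the first pair made a 4.9-fold higher number from compound 1 to compound 2 (0.69 log units; beyond the scatter); the different core leaves room for a somewhat smaller step. Compound 4 is therefore estimated at 15000 nM, expected to fall between 6000 nM and 40000 nM.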

Compound 4, concentration for 50% growth inhibition: 630 nM
Compound 4: middle estimate off by 24-fold (1.38 log units), on the high side, and the stated range ends above it.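

In this assay, methoxy in place of chloro on an aromatic carbon gave a 6.8-fold lower number from compound 3 to compound 4 (0.83 log units; beyond the scatter), so the direction of the step seen on the core of compound 1 did not carry over to the core of compound 3. The two steps run in opposite directions, and the gap between them is larger than the usual scatter: the same change on two cores in this assay, a 4.9-fold higher number (0.69 log units; beyond the scatter) from compound 1 to compound 2 and a 6.8-fold lower number (0.83 log units; beyond the scatter) from compound 3 to compound 4, 33-fold (1.52 log units) apart, beyond the scatter of two such steps. This shows that, in this series, the result of the swap on one core cannot simply be transferred to the other, but two pairs do not show which difference between the cores matters.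

The compounds shown leave open how an amine or an ethoxy group would compare with chloro and methoxy on each core. They also leave open which direction the step would take on a third core.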